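A benzyl group replaces a fluorophenyl at the fused core

The compounds below may be only part of what the source reports. "The series", "measured", "known", "first", "only" and "open" are said of these compounds alone.

Compound 3 `COc1cccc(CNCCCNc2ccnc3cc(-c4ccc(F)cc4)ccc23)c1O` gives 237 10^-6 cm/s in an ADME assay for permeability, using PAMPA, with a stated time of 30 min, at pH 7.4 (a higher number here means that the compound crosses the layer faster, a lower number that the compound crosses the layer more slowly), level with compound 2 `COc1cccc(CNCCCNc2ccnc3cc(-c4ccccc4)ccc23)c1O`, which gives 237 10^-6 cm/s; together they hold the highest of the three numbers, while compound 1 `CCC(CC)c1ccc2c(NCCCNCc3cccc(OC)c3O)ccnc2c1` gives 23 10^-6 cm/s. The step of a 10-fold higher number from compound 1 to compound 3 (1.01 log units; beyond the scatter) is large, and the step of no change at the digits printed from compound 2 to compound 3 (within the scatter) lies within the scatter. Compound 4 `COc1cccc(CNCCCNc2ccnc3cc(Cc4cc(C)cc(C)c4)ccc23)c1O` differs from compound 3 in one place: 3,5-dimethylbenzyl in place of 4-fluorophenyl on an aromatic carbon. Within the data shown here, no measured step exchanges an aryl for a benzyl at this place, so only the step of a 10-fold higher number from compound 1 to compound 3 (1.01 log units; beyond the scatter) and the step of no change at the digits printed from compound 2 to compound 3 (within the scatter) bear on it, indirectly. As compound 4 keeps a six-membered aromatic ring there, compound 4 is expected to give about 160 10^-6 cm/s, between 45 10^-6 cm/s and 400 10^-6 cm/s. The expected step of a 1.5-fold lower number from compound 3 to compound 4 (0.17 log units; within the scatter) is estimated to stay within the scatter.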

Compound 4, apparent permeability: 23 10^-6 cm/s
Estimate against measurement, compound 4: 7.0-fold (0.84 log units) above; measured number outside the range, below it.
By their numbers in this assay, from the lowest: compounds 1 and 4 (each within the scatter of the next); then compounds 2 and 3 (each within the scatter of the next).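

At this position, carrying over a six-membered aromatic ring of carbon only does not preserve the number in this assay: 3,5-dimethylbenzyl gives a 10-fold lower number from compound 3 to compound 4 (1.01 log units; beyond the scatter) and a 10-fold lower number from compound 2 to compound 4 (1.01 log units; beyond the scatter). It instead stands level with pentan-3-yl, with no change at the digits printed from compound 1 to compound 4 (within the scatter), so among these four compounds only phenyl and 4-fluorophenyl give the high numbers. Nothing shown here explains this difference.

On these data alone, whether the lower number goes with the methyl groups or with the benzyl carbon remains open. An unsubstituted benzyl or a 3,5-dimethylphenyl group at this place would separate the two.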